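Methoxy in Place of Chloro on the Aromatic Carbon

This account rests on a few compounds, and the source may have more. Where it says the series, first, only, none or still open, it means among the compounds named here.

Compound 2 `COC(=O)[C@@]1(C)CCC=C2[C@@H]1CC[C@@H](C)[C@]2(C)Cc1c(C)[nH]c2ccc(Cl)cc12` gives 15000 nM in a functional assay on HBL-100 cells (Homo sapiens) for inhibition, read by sulforhodamine B assay, with a stated time of 48 h (on this read-out lower numbers stand for stronger inhibition of growth and higher numbers for weaker inhibition of growth), the larger of the two numbers shown, though compound 1 `COC(=O)[C@@]1(C)CCC=C2[C@@H]1CC[C@@H](C)[C@]2(C)Cc1c(C)[nH]c2ccccc12` at 14000 nM sits within the scatter of it. Among the measured compounds shown here, the only step bearing on the next change is a 1.1-fold higher number from compound 1 to compound 2 (0.03 log units; within the scatter), which touched the same aromatic carbon. Compound 3 `COC(=O)[C@@]1(C)CCC=C2[C@@H]1CC[C@@H](C)[C@]2(C)Cc1c(C)[nH]c2ccc(OC)cc12` carries the difference (methoxy in place of chloro on an aromatic carbon). Since that one comparable step was small, no step beyond the scatter is expected in this assay. Compound 3 is therefore estimated at 15000 nM, within 6000 nM to 40000 nM, which amounts to an expected no change at the digits printed from compound 2 to compound 3 (within the scatter).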

Compound 3, concentration for 50% growth inhibition: 16000 nM
Estimate against measurement, compound 3: 1.1-fold (0.03 log units) below; the range from low to high includes it.
By their numbers in this assay, from the lowest: compounds 1, 2 and 3 (each within the scatter of the next).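

In this assay methoxy in place of chloro on this aromatic carbon gives a 1.1-fold higher number from compound 2 to compound 3 (0.03 log units; within the scatter) and methoxy in place of hydrogen gives a 1.1-fold higher number from compound 1 to compound 3 (0.06 log units; within the scatter) on the same carbon. Methoxy, which brings a hydrogen-bond acceptor that chloro and hydrogen lack, therefore joins them without any step beyond the scatter, so this read-out does not separate the three groups at this position. No evidence on hand accounts for this. From the compounds shown here alone, whether an amine or a carboxylic acid on this carbon would give a step beyond the scatter remains open.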